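Swapping Chloro for Dimethylamino in a Cytotoxicity Series

The source may report more compounds than this note shows. Statements on the series, on what has been measured and on what is new or still open speak of the compounds shown alone.

Of the compounds shown here, three with a shared core have been tested in a functional assay on MOLT-4 cells (Homo sapiens) for cytotoxicity, with a stated time of 72 h; a lower number here means a stronger inhibitor, a higher number a weaker inhibitor. Compound 1 `CN(C)c1ccc(/C=C2\CCC/C(=C\c3ccccc3[N+](=O)[O-])C2=O)cc1` gives 122000 nM, compound 2 `O=C1/C(=C/c2ccc(Cl)cc2)CCC/C1=C\c1ccc([N+](=O)[O-])cc1` gives 9120 nM, and compound 3 `O=C1/C(=C/c2ccc(Cl)cc2)CCC/C1=C\c1ccccc1[N+](=O)[O-]` gives 3860 nM. Compound 3 and compound 1 differ in one place: dimethylamino in place of chloro on an aromatic carbon. That change made a 32-fold higher number from compound 3 to compound 1 (1.50 log units; beyond the scatter). The difference between the cores of compound 2 and compound 3 is not broken down here. Compound 4 `CN(C)c1ccc(/C=C2\CCC/C(=C\c3ccc([N+](=O)[O-])cc3)C2=O)cc1`, not yet measured, relates to compound 2 by the same change: dimethylamino in place of chloro on an aromatic carbon. Because the earlier change produced a 32-fold higher number from compound 3 to compound 1 (1.50 log units; beyond the scatter), a step of similar size is expected from compound 2 to compound 4 in this assay, namely a 22-fold higher number from compound 2 to compound 4 (1.34 log units; beyond the scatter). Compound 4 is therefore estimated at 200000 nM in this assay, expected to lie between 60000 nM and 600000 nM.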

Compound 4, half-maximal inhibitory concentration: > 500000 nM
Compound 4 gave a limit, no number; the forecaster's own chance of this, stated with the estimate: 30%; middle value at least 2.5-fold (0.39 log units) away from the limit.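

In this assay compound 4 gave only a limit of the assay, > 500000 nM, and not a number. From the compounds shown here alone, on the core of compound 2, dimethylamino in place of chloro gave an at least 54-fold higher number from compound 2 to compound 4 (1.73 log units; beyond the scatter), so the change pointed the same way on both cores, but whether its size carries over stays unknown: the same change on two cores in this assay, a 32-fold higher number (1.50 log units; beyond the scatter) from compound 3 to compound 1 and an at least 54-fold higher number (1.73 log units; beyond the scatter) from compound 2 to compound 4; the limit leaves it open whether they differ. With dimethylamino present on both compounds, 4-nitrophenyl in place of 2-nitrophenyl gave an at least 4.0-fold higher number from compound 1 to compound 4 (0.61 log units; beyond the scatter).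

The compounds shown leave open how a group such as methoxy or a primary amine would compare with chloro and dimethylamino at this place. Among these compounds, only two cores carry the change, so its effect on a core without a nitro group also stays open.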